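This account rests on a few compounds, and the source may have more. Where it says the series, first, only, none or still open, it means among the compounds named here.

In a functional assay on A549 cells (Homo sapiens) for antiproliferative activity, read by MTT assay, with a stated time of 72 h (a lower number here means a stronger inhibitor, a higher number a weaker inhibitor), compound 1 `COc1cc(C(=O)c2sc3ccccc3c2-c2ccccc2)cc(OC)c1OC` gives 5000 nM, while compound 2 `COc1cc(C(=O)c2sc3ccccc3c2Nc2ccccc2)cc(OC)c1OC` gives 3000 nM and compound 3 `COc1ccc(Nc2c(C(=O)c3cc(OC)c(OC)c(OC)c3)sc3ccccc23)cc1` gives 9300 nM as the third reading. Compound 3 stands above compound 2 (a 3.1-fold higher number from compound 2 to compound 3 (0.49 log units; beyond the scatter)) and level with compound 1 (a 1.9-fold higher number from compound 1 to compound 3 (0.27 log units; within the scatter)). Compound 4 `CCOc1ccc(Nc2c(C(=O)c3cc(OC)c(OC)c(OC)c3)sc3ccccc23)cc1` turns the methoxy of compound 3 into ethoxy (methyl in place of hydrogen on a saturated chain carbon bound to an oxygen on an aromatic ring). The closest measured precedent is the step that introduced methoxy in place of hydrogen on compound 2 (a 3.1-fold higher number from compound 2 to compound 3 (0.49 log units; beyond the scatter)), which is modest. A single step sets no trend, so only a small further rise is expected (a 1.2-fold higher number from compound 3 to compound 4 (0.07 log units; within the scatter)), with no change beyond the scatter. For compound 4 the estimate is 11000 nM with 4500 nM to 27000 nM as the expected range.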

Compound 4, half-maximal inhibitory concentration: 1400 nM
For compound 4 the middle estimate is 7.9-fold (0.90 log units) above the measured one; measured number outside the range, below it.
By their numbers in this assay, from the lowest: compound 4; then compounds 2, 1 and 3 (each within the scatter of the next, the first and the last beyond it).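

In this assay, one added methyl on the alkoxy group reverses the direction seen with methoxy: methoxy raised the number (a 3.1-fold higher number from compound 2 to compound 3 (0.49 log units; beyond the scatter)), whereas ethoxy lowers it (a 6.6-fold lower number from compound 3 to compound 4 (0.82 log units; beyond the scatter)). Ethoxy also ends up ahead of the unsubstituted anilino compound (a 2.1-fold lower number from compound 2 to compound 4 (0.33 log units; beyond the scatter)) and the phenyl compound (a 3.6-fold lower number from compound 1 to compound 4 (0.55 log units; beyond the scatter)), so this position separates two alkoxy groups that differ by a single carbon. Nothing available explains this reversal.

Methoxy and ethoxy alone define no chain-length trend. As far as these compounds go, whether propoxy extends the lower number, or a hydroxy group or an amine at this place matches ethoxy, remains open.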